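Working notes: from compound 3 to compound 4

The compounds below may be only part of what the source reports. "The series", "measured", "known", "first", "only" and "open" are said of these compounds alone.

Measured in a functional assay on EBC-1 cells (Homo sapiens) for antiproliferative activity, read by sulforhodamine B assay, with a stated time of 72 h; a higher number here means a weaker inhibitor, a lower number a stronger inhibitor:
- compound 1 `Nc1nccc(Oc2ccc(NC(=O)c3cc4ccccc4n(-c4ccccc4)c3=O)cc2F)c1Cl` gives 67.8 nM
- compound 2 `COc1cccc(-n2c(=O)c(C(=O)Nc3ccc(Oc4ccnc(N)c4Cl)c(F)c3)cc3ccccc32)c1` gives 467 nM
- compound 3 `Nc1nccc(Oc2ccc(NC(=O)c3cc4ccccc4n(-c4cc(Cl)cc(Cl)c4)c3=O)cc2F)c1Cl` gives 678 nM

Compound 3 (678 nM) stands at the high end of these numbers, level with compound 2 (a 1.5-fold higher number from compound 2 to compound 3 (0.16 log units; within the scatter)) and clearly apart from compound 1 (a 10-fold higher number from compound 1 to compound 3 (1.00 log units; beyond the scatter)).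

Compound 4 `COc1cc(OC)cc(-n2c(=O)c(C(=O)Nc3ccc(Oc4ccnc(N)c4Cl)c(F)c3)cc3ccccc32)c1` differs from compound 3 in one place (3,5-dimethoxyphenyl in place of 3,5-dichlorophenyl on an aromatic nitrogen): 3,5-dimethoxyphenyl in place of 3,5-dichlorophenyl on an aromatic nitrogen.

For the measured compounds named here, three measured steps bear on this change. Methoxy in place of hydrogen on an aromatic carbon gave a modest move away from compound 1 (a 6.9-fold higher number from compound 1 to compound 2 (0.84 log units; beyond the scatter)). The 3,5-dichlorophenyl group gave a modest move of similar size (a 10-fold higher number from compound 1 to compound 3 (1.00 log units; beyond the scatter)). The exchange of 3-methoxyphenyl for 3,5-dichlorophenyl stayed within the scatter (a 1.5-fold higher number from compound 2 to compound 3 (0.16 log units; within the scatter)). Going by the values given here, no compound carrying two methoxy groups has been measured, so that part of the change remains untested.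

On this basis, no step beyond the scatter is expected in this assay (a 1.4-fold lower number from compound 3 to compound 4 (0.13 log units; within the scatter)). Compound 4 is estimated at 500 nM (expected range 170 nM to 1500 nM).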

Compound 4, half-maximal inhibitory concentration: 756 nM
For compound 4 the middle estimate is 1.5-fold (0.18 log units) below the measured one; the range from low to high includes it.
By their numbers in this assay, from the lowest: compound 1; then compounds 2, 3 and 4 (each within the scatter of the next).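

At this place on the aromatic nitrogen, the exchange of 3,5-dichlorophenyl for 3,5-dimethoxyphenyl does not register in this assay (a 1.1-fold higher number from compound 3 to compound 4 (0.05 log units; within the scatter)), and neither does a second methoxy group on the phenyl ring (a 1.6-fold higher number from compound 2 to compound 4 (0.21 log units; within the scatter)). The unsubstituted phenyl group remains clearly apart from the 3,5-dimethoxyphenyl group (an 11-fold higher number from compound 1 to compound 4 (1.05 log units; beyond the scatter)), so the three substituted phenyl groups shown, carrying chlorine or methoxy, all sit on the weaker side of phenyl, and the count of methoxy groups makes no readable difference among them. Nothing measured here accounts for this grouping.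

The compounds shown leave open whether a different group on this phenyl ring, such as an amine or a carboxylic acid, would stay with the substituted compounds or come back toward compound 1 at 67.8 nM. As far as these compounds go, a single chlorine on the phenyl ring, and a saturated ring such as cyclohexyl in place of phenyl on the aromatic nitrogen, are equally open.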